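Phenethyl for 4-Methylphenyl on the Thioether Sulfur

The compounds below may be only part of what the source reports. "The series", "measured", "known", "first", "only" and "open" are said of these compounds alone.

Compound 1 `Cc1ccc(SCc2ccc(C(=O)Nc3ccccc3N)cc2)cc1`: 3270 nM
Compound 2 `Nc1ccccc1NC(=O)/C=C/c1ccc(CSCCc2ccccc2)cc1`: 1150 nM

In a functional assay on A549 cells (Homo sapiens) for antiproliferative activity, read by CCK-8 assay, with a stated time of 72 h (a lower number here means a stronger inhibitor, a higher number a weaker inhibitor), compound 1 gives 3270 nM, the higher of the two numbers. Compound 2 gives 1150 nM, a gap beyond the usual scatter. Compound 3 `Nc1ccccc1NC(=O)c1ccc(CSCCc2ccccc2)cc1` is not yet measured; compared with compound 1 it carries phenethyl in place of 4-methylphenyl on a sulfur. A modest step toward a lower number is expected, a 2.0-fold lower number from compound 1 to compound 3 (0.31 log units; beyond the scatter), because compound 2 gives 1150 nM while already carrying a phenethyl on its sulfur, although the step may still fall within the scatter. Compound 3 is estimated at 1600 nM, with a range from 500 nM to 5000 nM.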

Compound 3, half-maximal inhibitory concentration: 3250 nM
Compound 3: the middle estimate sits 2.0-fold (0.31 log units) below what was measured, and the stated range covers the measured number.
By their numbers in this assay, from the lowest: compound 2; then compounds 3 and 1 (each within the scatter of the next).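

In this assay, replacing 4-methylphenyl with phenethyl on the sulfur gives a 1.0-fold lower number from compound 1 to compound 3 (0.00 log units; within the scatter), so this position tolerates the swap without a readable change. Compound 3 carries the same phenethyl as compound 2, yet compound 2 gives 1150 nM and compound 3 gives 3250 nM, so the phenethyl alone does not bring the lower number. No supporting data explain this result.

From the compounds shown here alone, whether a benzyl group or a longer chain ending in an amine on the sulfur would move the number remains open.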